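A few compounds are considered here, and "the series" means these few. Any claim that something is new, unique, unknown or untested is made for them only; others in the source may bear on it.

Measured so far in this series:
compound 1, `COc1cc(-c2cc3nccc(-c4c[nH]c5ccccc45)n3n2)cc(OC)c1OC`, > 10000 nM
compound 2, `COc1cc(-c2ccnc3cc(-c4ccccc4)nn23)cc(OC)c1OC`, 208 nM

Both entries come from a functional assay on A549 cells (Homo sapiens) for inhibition, read by CCK-8 assay, with a stated time of 48 h; a lower number here means a stronger inhibitor, a higher number a weaker inhibitor. Compound 1 carries the indole group on the shared core and returns only a limit in this assay, > 10000 nM. Compound 2 carries a plain phenyl at the same position and gives 208 nM in this assay. Among the compounds with values here, compound 2 therefore stands as the only real number measured; the other entry sits at the limit of > 10000 nM in this assay, at which 1 of the 2 values shown sits, so no measured step between two numbers exists yet, and the two structures differ in more than one place, so what they show together is only that the indole analogue is out of range while the phenyl analogue is active.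

Compound 3, `COc1ccc(-c2cc3nccc(-c4cc(OC)c(OC)c(OC)c4)n3n2)cc1`, differs from compound 2 by methoxy in place of hydrogen on an aromatic carbon. Nothing measured in the series speaks to this kind of change, so no direction can be read off the data. Compound 3 is expected to land at about 220 nM, within 60 nM to 800 nM. The expected step of a 1.1-fold higher number from compound 2 to compound 3 (0.02 log units; within the scatter) is thus no larger than the usual scatter, in either direction.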

Compound 3, half-maximal inhibitory concentration: 376 nM
For compound 3 the middle estimate is 1.7-fold (0.23 log units) below the measured one; the range from low to high includes it.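

In this assay the series now has its first step between two real numbers, a 1.8-fold higher number from compound 2 to compound 3 (0.26 log units; within the scatter) for methoxy in place of hydrogen on an aromatic carbon, which in the wider cut reads phenyl to 4-methoxyphenyl. This place, on a six-membered aromatic ring of carbon only and para to a large group, therefore accepts a methoxy group with no change that can be told apart from repeat-measurement scatter, and compound 3 stays in the same range as compound 2, something the earlier pair could not show. Nothing measured here bears on why this substitution leaves the read-out so close, and no property of the methoxy group can be drawn from the data.

Still open is how an amine, a carboxylic acid or a longer chain such as butoxy would read at this same place, since hydrogen and methoxy are the only two groups shown there. Also open, going by these compounds, is whether the result for methoxy carries over to a different group on the shared core, such as the indole of compound 1.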